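A few compounds are considered here, and "the series" means these few. Any claim that something is new, unique, unknown or untested is made for them only; others in the source may bear on it.

Working notes on the series. In an assay for activation of potassium voltage-gated channel subfamily KQT member 1 (Cavia porcellus) (a higher number here means a weaker inhibitor, a lower number a stronger inhibitor), compound 1 `CCCCc1noc(-c2ccc(C(=O)NC[C@H]3CCCC3(C)C)cc2)n1` gives 2 nM, the lowest number in this set. Compound 3 `CCCCCCOc1ccc(C(=O)NC2CCC(C)(C)C2)cc1` gives 360 nM, and compound 2 `Cc1noc(-c2ccc(C(=O)NCC3CCCC3(C)C)cc2)n1` gives 580 nM; 220 nM (2 entries) across repeated runs (the several entries of compound 2 in this assay, 580 nM; 220 nM (2 entries)); both stand well above compound 1, with no single change in this assay connecting any pair of them. Compound 4 `CCCCc1noc(-c2ccc(C(=O)NC[C@@H]3CCCC3(C)C)cc2)n1` is next: the two compounds have the same atoms and bonds and differ only in configuration as drawn: 1 of 1 stereo elements differ; a stereocentre at a saturated ring carbon is drawn S in compound 1 and R in compound 4. Among the measured compounds shown here, no measured pair in this assay shows how such a change alone shifts the number, so the expectation rests on compound 1 at 2 nM alone. A step of a 10-fold higher number from compound 1 to compound 4 (1.00 log units; beyond the scatter) toward a higher number is expected, beyond the scatter but with wide uncertainty. Compound 4 is estimated at 20 nM, between 3 nM and 200 nM.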

Compound 4, half-maximal inhibitory concentration: 9 nM
The estimate for compound 4 lay 2.2-fold (0.35 log units) above the measured number; the range from low to high includes it.
By their numbers in this assay, from the lowest: compound 1; then compound 4; then compound 3.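

In this assay, inverting the stereocentre at this saturated ring carbon from S to R gives a 4.5-fold higher number from compound 1 to compound 4 (0.65 log units; beyond the scatter), the first measured effect of configuration in this set. The step can be assigned to this stereocentre alone because nothing else changes: the fact that compounds 1 and 4 differ only in the configuration as drawn. The step is modest, and compound 4 still gives 9 nM.

From the compounds shown here alone, whether S again gives the lower number with another group on the shared core, such as a carboxylic acid or a primary amine in place of the butyl chain, remains open.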